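Flipping One Ring Stereocentre in a Compound with a Low Number

The source may report more compounds than this note shows. Statements on the series, on what has been measured and on what is new or still open speak of the compounds shown alone.

Compound 1 `O=C(/C=C/c1cn([C@@H]2C[C@H](CO)N(CCCc3ccccc3)C2)nn1)NO` is a hydroxamic acid that, in an assay on Sf9 cells for inhibition of histone deacetylase 11 (Homo sapiens), read by fluorescence, tested at 0.5 uM (on this read-out lower numbers stand for less inhibition and higher numbers for more inhibition at the one concentration tested (going by the name of the read-out)), gives 12%. Compound 2 `O=C(NO)c1ccc(-c2cn([C@H]3C[C@H](CO)N(CCCc4ccccc4)C3)nn2)cc1` gives 18% in this assay, a number within the scatter of the value for compound 1, so the two are not distinguishable here. For compound 3 `O=C(NO)c1cccc(-c2cn([C@@H]3C[C@H](CO)N(CCCc4ccccc4)C3)nn2)c1` the this assay result is a limit of the assay rather than a number, < 10%, as recorded by the limit of < 10% in this assay, at which 1 of the 3 values shown sits. Within the data shown here, the one measured step, a number at least 2 percentage points lower from compound 1 to compound 3 (that floor lies within the scatter), exchanges the group carrying the hydroxamic acid.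

Compound 4 `O=C(/C=C/c1cn([C@@H]2C[C@@H](CO)N(CCCc3ccccc3)C2)nn1)NO` keeps every atom and bond of compound 1 and differs only in configuration: the two compounds have the same atoms and bonds and differ only in configuration as drawn: 1 of 3 stereo elements differ; a stereocentre at a saturated ring carbon is drawn R in compound 1 and S in compound 4. Among the measured compounds shown here, no measured step changes a stereocentre alone, so the measured steps offer no direct guide; all values seen lie near the floor of this assay. The expectation is therefore a step of about no change at the digits printed from compound 1 to compound 4 (within the scatter), within the scatter. Compound 4 is estimated at 12%, ranging from 5% to 25%.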

Compound 4, a percentage reported as inhibition, at one concentration (the size of the read-out at that concentration, not a potency): 13%
For compound 4 the middle estimate is 1 percentage points below the measured one, and the stated range covers the measured number.
By their numbers in this assay, from the lowest: compounds 1, 4 and 2 (each within the scatter of the next). At a limit, below all of these: compound 3.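

The step to the S drawing at this saturated ring carbon is a number 1 percentage points higher from compound 1 to compound 4 (within the scatter) in this assay, so this one change of configuration does not separate the two compounds. The comparison is a clean one, with no other part of the structure altered: the fact that compounds 1 and 4 differ only in the configuration as drawn. The result is still a weak guide to this stereocentre, since the numbers in this series lie close to the bottom of what the assay can report: the limit of < 10% in this assay, at which 1 of the 4 values shown sits.

The compounds shown leave open whether inverting this stereocentre would matter in a compound with a clearly higher number, or on the compounds that carry a phenyl ring in place of the ethenyl link. They also leave open what a carboxylic acid or an amine would do in place of the hydroxymethyl group at the neighbouring part of the core.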